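The compounds below may be only part of what the source reports. "The series", "measured", "known", "first", "only" and "open" are said of these compounds alone.

Compound 1 `CC(C)CCn1c(Cn2c(=O)n(C3CC3)c3ccncc32)nc2nc(Cl)ccc21` gives > 50000 nM.
Compound 2 `CS(=O)(=O)CCCn1c(Cn2c(=O)n(C3CC3)c3ccncc32)nc2nc(Cl)ccc21` gives > 50000 nM.
Compound 3 `CC(C)CCn1c(Cn2c(=O)n(C3CC3)c3ccncc32)cc2cnccc21` gives > 50000 nM.

Each of these three values is a limit of an ADME assay on HeLa cells (Homo sapiens) for cytotoxicity, read by ATP content, with a stated time of 3 days (on this read-out lower numbers stand for higher toxicity in this test and higher numbers for lower toxicity in this test), and not a number. Compound 1 and compound 2 share one core; compound 2 differs from compound 1 by (methylsulfonyl)methyl in place of isopropyl on a saturated chain carbon, two bonds along the chain from an aromatic nitrogen. The step from compound 1 to compound 2 is a step that the two limits leave unreadable from compound 1 to compound 2, because both values sit at the limit of > 50000 nM in this assay, at which 3 of the 3 values shown sit. Compound 3 rests on a different core, and the difference between the two cores is not broken down here.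

Compound 4 `CS(=O)(=O)CCCn1c(Cn2c(=O)n(C3CC3)c3ccncc32)cc2cnccc21` is not yet measured. It differs from compound 3 by (methylsulfonyl)methyl in place of isopropyl on a saturated chain carbon, two bonds along the chain from an aromatic nitrogen, the same change in the same place. Compound 4 is expected to give 50000 nM, a step of a number no higher from compound 3 to compound 4 (the limit leaves the size open). This expectation rests on compound 3 giving > 50000 nM. It also rests on compound 2 giving > 50000 nM.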

Compound 4, half-maximal cytotoxic concentration: > 50000 nM
Compound 4: a limit, no number; the forecaster's own chance of this, stated with the estimate: 85%; the middle value sits exactly at the limit.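

No step can be read between compound 3 and compound 4, because both values are limits and sit at the same one: the limit of > 50000 nM in this assay, at which 4 of the 4 values shown sit.
The compounds shown leave open how toxic any of them is in this assay, and whether (methylsulfonyl)methyl in place of isopropyl changes that at all.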